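The compounds below may be only part of what the source reports. "The series", "measured", "known", "first", "only" and "open" are said of these compounds alone.

Within the data shown here, compound 2 `O=C1O[C@@H](CN2CCCCC2)CN1c1ccc(-n2cc(-c3ccccn3)cn2)c(F)c1` gives 3.1 in a physicochemical assay for lipophilicity, read by HPLC, measured as octanol-water partition (on this read-out higher numbers stand for higher lipophilicity and lower numbers for lower lipophilicity), the higher of the two numbers measured so far. Among the measured compounds shown here, compound 1 `CN1CCN(C[C@H]2CN(c3ccc(-n4cc(-c5ccccn5)cn4)c(F)c3)C(=O)O2)CC1` gives 2.2 in this assay, and the single step between them, a number 0.90 log units higher from compound 1 to compound 2 (beyond the scatter), came from exchanging one saturated nitrogen ring for another on a saturated chain carbon bound to a saturated ring carbon. Compound 3 `O=C(OC[C@H]1CN(c2ccc(-n3cc(-c4ccccn4)cn3)c(F)c2)C(=O)O1)c1ccccc1` is changed at the same place: benzoyloxy in place of piperidin-1-yl on a saturated chain carbon bound to a saturated ring carbon. For the measured compounds named here, only the step from compound 1 to compound 2 touches this position, and it replaced one ring amine with another, whereas here a ring amine is exchanged for an ester bearing an aromatic ring, so that step is only a rough guide. On the counts given for compound 3, an upward step is expected, a number 0.80 log units higher from compound 2 to compound 3 (beyond the scatter), beyond the scatter. Compound 3 is therefore estimated at 3.9, within 3.3 to 4.5.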

Compound 3, partition coefficient: 4.21
The estimate for compound 3 lay 0.31 log units below the measured number; low and high end bracket the measured number.
By their numbers in this assay, from the lowest: compound 1; then compound 2; then compound 3.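

Among these compounds, the first step at this position only exchanged one saturated nitrogen ring for another, but this change leaves the ring amines altogether: in this assay, benzoyloxy in place of piperidin-1-yl gives a number 1.11 log units higher from compound 2 to compound 3 (beyond the scatter) and still moves the number upward. Set against the other ring amine, benzoyloxy in place of 4-methylpiperazin-1-yl gives a number 2.01 log units higher from compound 1 to compound 3 (beyond the scatter) on the same shared core, so this single position can shift the read-out widely. No measured evidence is available to explain these steps.

Benzoyloxy brings an ester link and an aromatic ring together, and the compounds shown do not tell their shares apart. An acetoxy group, with the ester but no aromatic ring, or a benzyloxy group, with the aromatic ring but no carbonyl, would separate them.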